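The source may hold more compounds than are shown below. What is called first, only, known or untested is meant among the compounds shown, and "the series" means these compounds.

Measured in a functional assay on A549 cells (Homo sapiens) for antiproliferative activity, read by MTT assay, with a stated time of 48 h; on this read-out lower numbers stand for stronger inhibition and higher numbers for weaker inhibition:
- compound 1 `COc1cc(-c2nnc3c(OCC(F)(F)F)cc(-c4ccc5[nH]ccc5c4)cn23)cc(OC)c1OC`: 585 nM
- compound 2 `COc1cc(-c2nnc3c(OC)cc(-c4ccc5c(ccn5C)c4)cn23)cc(OC)c1OC`: 69 nM
- compound 3 `COc1cc(-c2nnc3c(OC(C)C)cc(-c4ccc5c(ccn5C)c4)cn23)cc(OC)c1OC`: 322 nM

In this assay, compound 3 lies within the scatter of compound 1 and clearly above compound 2. Compound 4 `COc1cc(-c2nnc3c(OCC(F)(F)F)cc(-c4ccc5c(ccn5C)c4)cn23)cc(OC)c1OC` differs from compound 3 by one change: 2,2,2-trifluoroethyl in place of isopropyl on an oxygen on an aromatic ring. Within the data shown here, the only measured step at this oxygen is a 4.7-fold higher number from compound 2 to compound 3 (0.67 log units; beyond the scatter), and it does not involve 2,2,2-trifluoroethyl. Compound 1 carries the same 2,2,2-trifluoroethoxy and gives 585 nM, but it differs from compound 4 elsewhere. No change beyond the scatter is therefore expected, and the estimated step is a 1.1-fold higher number from compound 3 to compound 4 (0.04 log units; within the scatter). Compound 4 is estimated at 350 nM, with an expected range of 140 nM to 800 nM.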

Compound 4, half-maximal inhibitory concentration: 614 nM
Estimate against measurement, compound 4: 1.8-fold (0.24 log units) below, within the range that was stated.
By their numbers in this assay, from the lowest: compound 2; then compounds 3, 1 and 4 (each within the scatter of the next).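

In this assay the step of a 1.9-fold higher number from compound 3 to compound 4 (0.28 log units; within the scatter) means that 2,2,2-trifluoroethyl and isopropyl on this oxygen cannot be told apart. Trifluoromethyl in place of hydrogen on the chain carbon bound to this oxygen gives an 8.9-fold higher number from compound 2 to compound 4 (0.95 log units; beyond the scatter) and so separates compound 4 from the methoxy compound 2. The step of a 1.0-fold higher number from compound 1 to compound 4 (0.02 log units; within the scatter) shows that, with 2,2,2-trifluoroethoxy in place, methyl in place of hydrogen on the aromatic nitrogen stays within the scatter.

On these data alone, whether a plain ethyl or a longer chain carrying an amine on this oxygen would lie nearer compound 2 or compound 4 remains open. No evidence at hand accounts for the size of these steps.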